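The compounds below may be only part of what the source reports. "The series", "measured", "known", "first", "only" and "open" are said of these compounds alone.

Three compounds share a core in which an amide and a sulfonamide are joined through a central ring, and they differ only in the aromatic ring that sits on the sulfonyl sulfur. Compound 1 `O=C(NCc1ccc(CNS(=O)(=O)c2ccc(Cl)cc2)cc1)c1ccc(F)cc1` carries a 4-chlorophenyl there, compound 2 `O=C(NCc1ccc(CNS(=O)(=O)c2ccc([N+](=O)[O-])cc2)cc1)c1ccc(F)cc1` a 4-nitrophenyl, and compound 3 `O=C(NCc1ccc(CNS(=O)(=O)c2ccccc2F)cc1)c1ccc(F)cc1` a 2-fluorophenyl. In an assay on MDA-MB-231 cells for binding affinity to C-X-C chemokine receptor type 4 (Homo sapiens), read by fluorescence and microscopy, with stated times of 10 min and 30 min (a higher number here means that more compound is needed for the effect, a lower number that less compound is needed), compound 1 gives 100 nM, compound 2 gives 1000 nM, and compound 3 gives 10 nM. Compound 3 stands lowest of the three: a 10-fold lower number from compound 1 to compound 3 (1.00 log units; beyond the scatter), a 100-fold lower number from compound 2 to compound 3 (2.00 log units; beyond the scatter), and between the other two a 10-fold higher number from compound 1 to compound 2 (1.00 log units; beyond the scatter).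

Compound 4 `Cc1cccc(S(=O)(=O)NCc2ccc(CNC(=O)c3ccc(F)cc3)cc2)c1` has not yet been measured in this assay. Its change from compound 3 is 3-methylphenyl in place of 2-fluorophenyl on a sulfonyl sulfur. All three measured steps concern this same ring, and each of them moved the number well beyond the scatter, so a swap at this position is not expected to be neutral. Going by the values given here, no measured compound carries a methyl group on this ring, so the direction is uncertain; what can be said is that compound 3 holds the lowest number and every other variant of this ring gave a higher one. A moderate rise is therefore expected, with a 10-fold higher number from compound 3 to compound 4 (1.00 log units; beyond the scatter). Compound 4 is estimated to give 100 nM, within a range from 20 nM to 600 nM.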

Compound 4, effective concentration (reported as EC, without a stated level of effect): 1 nM
Estimate against measurement, compound 4: 100-fold (2.00 log units) above; the measured number lies below the stated range.
By their numbers in this assay, from the lowest: compound 4; then compound 3; then compound 1; then compound 2.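

The earlier compounds shown here could not show whether any ring on this sulfonyl sulfur would go lower than the 2-fluorophenyl of compound 3, and the 3-methylphenyl does: in this assay there is a 10-fold lower number from compound 3 to compound 4 (1.00 log units; beyond the scatter) between these two rings. The gaps to the other two rings are wider, with a 100-fold lower number from compound 1 to compound 4 (2.00 log units; beyond the scatter) and a 1000-fold lower number from compound 2 to compound 4 (3.00 log units; beyond the scatter) on the same assay, so compound 4 now holds the lowest of the four numbers, and it is the only one of the four whose ring on this sulfur carries neither a halogen nor a nitro group. No measurement of any property of these rings is at hand to account for this order.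

The 2-fluorophenyl and the 3-methylphenyl differ both in the group they carry and in where it sits on the ring, so the compounds shown cannot separate those two changes. From the compounds shown here alone, it also remains open whether a longer chain than methyl, an amine or a carboxylic acid on this ring would keep the number this low, and whether the order of the rings would hold if the rest of the shared core were changed.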